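This account rests on a few compounds, and the source may have more. Where it says the series, first, only, none or still open, it means among the compounds named here.

In a functional assay on NCI-H1299 cells (Homo sapiens) for antiproliferative activity, read by MTT assay, with a stated time of 48 h (on this read-out higher numbers stand for weaker inhibition and lower numbers for stronger inhibition), the measured compounds stand as follows.

Compound 1 `N#CC1=C(N)Oc2cc3oc(-c4ccccc4)cc(=O)c3c(O)c2C12C(=O)N(Cc1ccccc1)c1ccc(Cl)cc12`: > 50000 nM, a limit of the assay.
Compound 2 `N#CC1=C(N)Oc2cc3oc(-c4ccccc4)cc(=O)c3c(O)c2C12C(=O)N(Cc1ccccc1)c1ccc(Br)cc12`: > 50000 nM, a limit of the assay.
Compound 3 `CCN1C(=O)C2(C(C#N)=C(N)Oc3cc4oc(-c5ccc(OC)cc5OC)cc(=O)c4c(O)c32)c2cc(Cl)ccc21`: > 50000 nM, a limit of the assay.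

All three values sit at the limit of > 50000 nM in this assay, at which 3 of the 3 values shown sit. Compound 2 differs from compound 1 by bromo in place of chloro on an aromatic carbon. The step that the two limits leave unreadable from compound 1 to compound 2 cannot be read, as both ends are limits. The difference between the core of compound 1 and the core of compound 3 is not broken down here.

Compound 4 `CCN1C(=O)C2(C(C#N)=C(N)Oc3cc4oc(-c5ccc(OC)cc5OC)cc(=O)c4c(O)c32)c2cc(Br)ccc21` is not yet measured. It differs from compound 3 by bromo in place of chloro on an aromatic carbon, the same change as from compound 1 to compound 2, at a place described in identical words. The step from compound 3 to compound 4 is expected to be a number no higher from compound 3 to compound 4 (the limit leaves the size open), because compound 3 gives > 50000 nM, a limit, and the same change left compound 1 and compound 2 both at the limit. Compound 4 is therefore estimated at 50000 nM, between 20000 nM and 100000 nM, most probably reported again only as a limit.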

Compound 4, half-maximal inhibitory concentration: > 50000 nM
Compound 4 ended at the assay's limit; the forecaster's own chance of this, stated with the estimate: 85%; the middle value lies on the limit itself.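

No step can be read from compound 3 to compound 4, since both values are limits and not numbers: the limit of > 50000 nM in this assay, at which 4 of the 4 values shown sit.

The compounds shown leave open whether bromo and chloro differ in effect on either core.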